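A Longer Chain on Compound 3

This account rests on a few compounds, and the source may have more. Where it says the series, first, only, none or still open, it means among the compounds named here.

Measured in a functional assay on SK-MEL-28 cells (Homo sapiens) for antiproliferative activity; a lower number here means a stronger inhibitor, a higher number a weaker inhibitor:
Compound 1 `O=c1[nH]c(=O)n([C@@H]2C=C[C@@H](CO)O2)cc1F` gives 9800 nM
Compound 2 `O=c1[nH]c(=O)n([C@@H]2C=C[C@H](CO)O2)cc1F` gives 7450 nM
Compound 3 `CC(=O)OC[C@@H]1C=C[C@H](n2cc(F)c(N)nc2=O)O1` gives > 100000 nM as a limit of the assay

Compound 3 gives no number in this assay and stands only at its limit of > 100000 nM in the table above. This position is the limit of > 100000 nM in this assay, at which 1 of the 3 values shown sits, and so the starting point for the step is a bound and not a value.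

Compound 4 `CCCCC(=O)OC[C@@H]1C=C[C@H](n2cc(F)c(N)nc2=O)O1` differs from compound 3 by propyl in place of hydrogen on a saturated chain carbon bound to a carbonyl carbon and so acetoxy becomes (butylcarbonyl)oxy.

For the measured compounds named here, the only measured step is a 1.3-fold lower number from compound 1 to compound 2 (0.12 log units; within the scatter) and it reflects the fact that compounds 1 and 2 differ only in the configuration as drawn so it says nothing about the length of this chain. Going by the values given here, no measured step therefore bears directly on the change, and the data give no direction for it. No clear shift beyond the scatter is expected, and the assay may again report only a limit for compound 4.

The expected change, as an estimate only, is an at least 1.1-fold lower number from compound 3 to compound 4 (0.04 log units; that floor lies within the scatter) here. For compound 4 the estimated value is 90000 nM with an expected range from 30000 nM to 150000 nM in this assay.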

Compound 4, half-maximal inhibitory concentration: > 100000 nM
Compound 4 gave a limit, no number; the forecaster's own chance of this, stated with the estimate: 60%; at least 1.1-fold (0.04 log units) between middle value and limit.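

In this assay compound 4 gives only a limit, as compound 3 does, so no step can be read between compound 3 and compound 4, because both stand at the same limit: the limit of > 100000 nM in this assay, at which 2 of the 4 values shown sit. The compounds shown leave open whether going from acetoxy to (butylcarbonyl)oxy changes the antiproliferative activity of this pair at all, and in which direction.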